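Ring amine nitrogen substituent: ethyl to hydrogen

The source may report more compounds than this note shows. Statements on the series, on what has been measured and on what is new or still open speak of the compounds shown alone.

Measured compounds in an assay on isolated protein for binding affinity to sodium- and chloride-dependent glycine transporter 1 (Homo sapiens); a higher number here means a weaker inhibitor, a lower number a stronger inhibitor:
compound 1, `Cn1cnc(C(=O)N(Cc2cccc(OC(F)(F)F)c2)C[C@H]2[C@@H]3CN(CC4CC4)C[C@@H]32)c1`, gives 2.32 nM.
compound 2, `CN1C[C@@H]2[C@H](C1)[C@H]2CN(Cc1cccc(OC(F)(F)F)c1)C(=O)c1cn(C)cn1`, gives 2.32 nM.
compound 3, `CCN1C[C@@H]2[C@H](C1)[C@H]2CN(Cc1cccc(Cl)c1)C(=O)c1cn(C)cn1`, gives 4.58 nM.

Compound 3 has the highest of the three numbers, yet its gaps to compound 1 and to compound 2 both fall within the scatter, so the three compounds are treated as equivalent on this assay.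

Compound 4, `Cn1cnc(C(=O)N(Cc2cccc(Cl)c2)C[C@H]2[C@@H]3CNC[C@@H]32)c1`, is not yet measured. It differs from compound 3 by hydrogen in place of ethyl on an amine nitrogen in a ring.

For the measured compounds named here, one measured step bears on this change: no change at the digits printed from compound 1 to compound 2 (within the scatter). There the group removed sat on a saturated chain carbon bound to the ring amine nitrogen rather than on that nitrogen itself, so the precedent is indirect. Nothing measured here shows a shift on this assay from trimming a small group in this region, and no bare ring amine nitrogen has been measured in the series. The expectation is therefore a step of about a 1.1-fold higher number from compound 3 to compound 4 (0.04 log units; within the scatter), with added uncertainty for the lack of a direct precedent. Compound 4 is estimated at 5 nM, within a range of 1.8 nM to 14 nM.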

Compound 4, inhibition constant: 95.3 nM
The estimate for compound 4 lay 19-fold (1.28 log units) below the measured number; the whole stated range lies below it.
By their numbers in this assay, from the lowest: compounds 1, 2 and 3 (each within the scatter of the next); then compound 4.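

In this assay, for the compounds shown here, the amine nitrogen in the ring is the first place where a single change falls beyond the scatter: hydrogen in place of ethyl gives a 21-fold higher number from compound 3 to compound 4 (1.32 log units; beyond the scatter). The earlier step, hydrogen in place of cyclopropyl on the chain carbon bound to that nitrogen, gave no change at the digits printed from compound 1 to compound 2 (within the scatter) and left a carbon substituent on the nitrogen, so it could not show what a bare ring amine nitrogen costs. Nothing on hand accounts for the size of this step.

The compounds shown leave open whether any carbon substituent on this nitrogen is enough, or whether an acetyl group or a longer chain such as propyl would behave differently. Going by these compounds, it also remains open whether the same loss appears with trifluoromethoxy in place of chlorine on the benzyl ring.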